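The source may hold more compounds than are shown below. What is called first, only, known or untested is meant among the compounds shown, and "the series" means these compounds.

Measured compounds in a functional assay on CHO-K1 cells with Glucose-dependent insulinotropic receptor (Homo sapiens) as the target, read by a luciferase reporter, with a stated time of 5 h; a lower number here means a smaller maximal response, a higher number a larger maximal response:
compound 1 `CC(C)OC(=O)N1CCC(Oc2ncnc3c2CCN3c2ccc(S(C)(=O)=O)cc2F)CC1`: 91%
compound 2 `CC(C)OC(=O)N1CCC(Oc2ncnc3c2CCN3c2ccc(S(C)(=O)=O)cn2)CC1`: 111%
compound 3 `CC(C)OC(=O)N1CCC(Oc2ncnc3c2CCN3c2ccc(S(C)(=O)=O)nc2)CC1`: 97%

Compound 3 stands second highest of the three; its gap to compound 1 lies within the scatter, while a number 14 percentage points lower from compound 2 to compound 3 (beyond the scatter) lies beyond it. Compound 4 `CC(C)OC(=O)N1CCC(Oc2ncnc3c2CCN3c2ccc(C#N)cn2)CC1` differs from compound 3 in one place: 5-cyanopyridin-2-yl in place of 6-(methylsulfonyl)pyridin-3-yl on a nitrogen on an aromatic ring in a ring. Going by the values given here, the step that bears on this is the reverse of a number 14 percentage points lower from compound 2 to compound 3 (beyond the scatter), since the point of attachment of the pyridine returns to that of compound 2; the exchange of methylsulfonyl for the nitrile has no measured counterpart, and a number 20 percentage points higher from compound 1 to compound 2 (beyond the scatter) only confirms that the pyridin-2-yl attachment gave the largest maximum seen. A modest rise is therefore expected, a number 8 percentage points higher from compound 3 to compound 4 (within the scatter), with wide uncertainty. The expected value for compound 4 in this assay is 105%, ranging from 88% to 122%.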

Compound 4, largest response reached (reported as percent of maximum), in percent of the reference or control that the assay uses: 105%
Compound 4: the middle estimate sits on the measured number at the digits printed; the measured number falls inside the stated range.
By their numbers in this assay, from the lowest: compounds 1, 3, 4 and 2 (each within the scatter of the next, the first and the last beyond it).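

In this assay, the nitrile can stand in for methylsulfonyl on an aromatic carbon without a change beyond the scatter: a number 6 percentage points lower from compound 2 to compound 4 (within the scatter). The 5-cyanopyridin-2-yl group also keeps clear of the fluorinated phenyl group, with a number 14 percentage points higher from compound 1 to compound 4 (beyond the scatter), though it is not separated from 6-(methylsulfonyl)pyridin-3-yl, with a number 8 percentage points higher from compound 3 to compound 4 (within the scatter). No measurement here explains these results.

Open, from the compounds shown here alone, is whether a primary amide or a carboxylic acid on that aromatic carbon would hold the maximal response. Also open, going by these compounds, is how the nitrile reads on the pyridin-3-yl attachment.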